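Aryl swap on an aromatic nitrogen: notes on compounds 1 to 3

This account rests on a few compounds, and the source may have more. Where it says the series, first, only, none or still open, it means among the compounds named here.

Compound 1, `COc1ccccc1-n1nncc1CN1C(=O)C2(C(C#N)=C(N)Oc3c2c2nc4ccccc4nc2c2ccccc32)c2ccccc21`, in a functional assay on A549 cells (Homo sapiens) for antiproliferative activity, read by MTT assay, with a stated time of 48 h; a lower number here means a stronger inhibitor, a higher number a weaker inhibitor: > 50000 nM.
Compound 2, `Cc1ccc(-n2nncc2CN2C(=O)C3(C(C#N)=C(N)Oc4c3c3nc5ccccc5nc3c3ccccc43)c3ccccc32)c(C)c1`, in this assay: > 50000 nM.

Both values are limits of this assay and not numbers. The step that the two limits leave unreadable from compound 1 to compound 2 therefore cannot be read, because of the limit of > 50000 nM in this assay, at which 2 of the 2 values shown sit. Compound 2 stands at that limit. Compound 3, `Cc1ccc(-n2nncc2CN2C(=O)C3(C(C#N)=C(N)Oc4c3c3nc5ccccc5nc3c3ccccc43)c3ccccc32)cc1Cl`, differs from it in one place: 3-chloro-4-methylphenyl in place of 2,4-dimethylphenyl on an aromatic nitrogen. For the measured compounds named here, the single measured step bears on this change but gives no readable size, so no direction can be drawn from it. A step of a number no higher from compound 2 to compound 3 (the limit leaves the size open) is expected. Compound 3 is estimated at 50000 nM, with a range from 20000 nM to 100000 nM, and most likely this assay again reports only a limit.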

Compound 3, half-maximal inhibitory concentration: > 50000 nM
Compound 3 was reported as a limit (the forecaster's own chance of this, stated with the estimate: 75%); the middle value lies on the limit itself.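

For the compounds shown here, no step among compound 1, compound 2 and compound 3 can be read, because in this assay all three give only a limit: the limit of > 50000 nM in this assay, at which 3 of the 3 values shown sit. Left open is how these three aryl groups compare and at what concentration, if any, each compound acts.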